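Notes on the series: from compound 1 toward compound 3

The compounds below may be only part of what the source reports. "The series", "measured", "known", "first", "only" and "open" are said of these compounds alone.

Measured so far in a functional assay on A549 cells (Homo sapiens) for cytotoxicity, read by MTT assay, with a stated time of 48 h; on this read-out higher numbers stand for weaker inhibition and lower numbers for stronger inhibition:
compound 1 `Cc1nnc(SCc2ccccc2)n1N1C(=O)c2ccccc2C1=O`: > 200000 nM
compound 2 `Cc1nnc(SCc2ccccc2Cl)n1N1C(=O)c2ccccc2C1=O`: > 200000 nM

Compound 1 stands only at a limit in this assay; its value is a limit, not a number. Compound 2 likewise reports a limit. Among the compounds with values here, both values sit at the limit of > 200000 nM in this assay, at which 2 of the 2 values shown sit, so the one measured step, a step that the two limits leave unreadable from compound 1 to compound 2, has no readable size or direction. Compound 3 `CCc1nnc(SCc2ccccc2)n1N1C(=O)c2ccccc2C1=O` differs from compound 1 by methyl in place of hydrogen on a saturated chain carbon bound to an aromatic carbon. Within the data shown here, no measured step speaks to this change, so neither a size nor a direction can be taken from the data. Compound 3 is therefore expected near 200000 nM (range 50000 nM to 300000 nM), most likely again as a limit, the expected step being a number no higher from compound 1 to compound 3 (the limit leaves the size open).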

Compound 3, half-maximal inhibitory concentration: > 200000 nM
Compound 3: only a limit was reported; the forecaster's own chance of this, stated with the estimate: 85%; the middle value sits exactly at the limit.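

Compound 1 and compound 3 both report only a limit in this assay, so no step can be read between them: the limit of > 200000 nM in this assay, at which 3 of the 3 values shown sit.

The compounds shown leave open what size or direction either the chloro or the methyl change has on the shared core.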